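The source may hold more compounds than are shown below. What is called first, only, known or untested is meant among the compounds shown, and "the series" means these compounds.

The measured compounds, with their values in an assay on CHO-K1 cells for antagonist activity at transient receptor potential cation channel subfamily V member 1 (Homo sapiens), read by FLIPR and calcium flux, with a stated time of 6 min; on this read-out higher numbers stand for weaker inhibition and lower numbers for stronger inhibition:
Compound 1 `O=C(NCc1cc(C(F)(F)F)nn1-c1cccc(Cl)c1)Nc1cccc2[nH]ncc12` gives 0.9 nM.
Compound 2 `O=C(NCc1cc(C(F)(F)F)nn1-c1ccc(Cl)cc1)Nc1cccc2[nH]ncc12` gives 2.5 nM.
Compound 3 `CC(C)c1ccc(-n2nc(C(F)(F)F)cc2CNC(=O)Nc2cccc3[nH]ncc23)cc1` gives 4.1 nM.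

Compound 3 carries the highest number of the three. The step of a 1.6-fold higher number from compound 2 to compound 3 (0.21 log units; within the scatter) lies within the scatter, so the two cannot be told apart. The step of a 4.6-fold higher number from compound 1 to compound 3 (0.66 log units; beyond the scatter) lies beyond the scatter, so compound 3 is a weaker inhibitor than compound 1.

Compound 4 `O=C(NCc1cc(C(F)(F)F)nn1-c1ccc(F)c(Cl)c1)Nc1cccc2[nH]ncc12` differs from compound 3 in one place: 3-chloro-4-fluorophenyl in place of 4-isopropylphenyl on an aromatic nitrogen. Going by the values given here, two measured steps bear on this change. The step of a 4.6-fold higher number from compound 1 to compound 3 (0.66 log units; beyond the scatter) shows that 4-isopropylphenyl in place of 3-chlorophenyl raised the number modestly, and the step of a 1.6-fold higher number from compound 2 to compound 3 (0.21 log units; within the scatter) shows that isopropyl in place of chloro made no difference beyond the scatter. Among the compounds with values here, compound 4 brings back a chlorine in the 3-position, as in compound 1, and adds a fluorine in the 4-position, for which no measured compound gives a precedent, so the range is kept wide. A modest step toward a lower number is expected. Compound 4 is expected to give 1.3 nM in this assay. The expected range for compound 4 runs from 0.5 nM to 3.5 nM. This estimate means an expected step of a 3.2-fold lower number from compound 3 to compound 4 (0.50 log units; beyond the scatter).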

Compound 4, inhibition constant: 0.6 nM
For compound 4 the middle estimate is 2.2-fold (0.34 log units) above the measured one; low and high end bracket the measured number.
By their numbers in this assay, from the lowest: compounds 4 and 1 (each within the scatter of the next); then compounds 2 and 3 (each within the scatter of the next).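

Putting 3-chloro-4-fluorophenyl on the aromatic nitrogen in place of 4-isopropylphenyl gives a 6.8-fold lower number from compound 3 to compound 4 (0.83 log units; beyond the scatter), and putting it in place of 4-chlorophenyl gives a 4.2-fold lower number from compound 2 to compound 4 (0.62 log units; beyond the scatter), so this position still responds clearly to the pattern of groups on the phenyl ring. Adding the fluoro to the 3-chlorophenyl of compound 1 gives a 1.5-fold lower number from compound 1 to compound 4 (0.18 log units; within the scatter), which lies within the scatter, so with the 3-chloro kept, a fluoro in the 4-position leaves the number unchanged, and a group there need not raise it. Nothing given here accounts for these differences.

Going by these compounds, it remains open whether a larger group alongside the 3-chloro, such as a methoxy or a trifluoromethyl in place of the fluoro, would keep the number this low. On these data alone, it is equally open how an amine on the phenyl ring, or a pyridine in place of that ring, would fare.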